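The source may hold more compounds than are shown below. What is called first, only, known or untested is meant among the compounds shown, and "the series" means these compounds.

Measured so far:
Compound 1 `O=C(NCCCCN1CCCCC1)Nc1ccc(-c2ccccc2)nc1` gives > 30000 nM in a functional assay on HEK293 cells for agonist activity at 5-hydroxytryptamine receptor 3A (Homo sapiens), read by FLIPR; a lower number here means a stronger inhibitor, a higher number a weaker inhibitor; this is a limit of the assay, not a number.
Compound 2 `COc1ccccc1-c1ccc(NC(=O)NCCCCN2CCCCC2)cn1` gives > 30000 nM in this assay; this, too, is a limit.

Compound 2 therefore stands at the limit of the assay, and no number for it is known. Among the measured compounds shown here, the one step measured so far, a step that the two limits leave unreadable from compound 1 to compound 2, runs between two limits and its size cannot be read. Both values sit at the same limit (the limit of > 30000 nM in this assay, at which 2 of the 2 values shown sit).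

Compound 3 `O=C(NCCCCN1CCCCC1)Nc1ccc(-c2ccccc2F)nc1` differs from compound 2 by fluoro in place of methoxy on an aromatic carbon. For the measured compounds named here, no measured step bears on this change: the step from compound 1 to compound 2 is unreadable, and no other pair is known. Going by the values given here, the only guide is that both measured compounds sit at the limit (the limit of > 30000 nM in this assay, at which 2 of the 2 values shown sit).

A step that the limit leaves unreadable from compound 2 to compound 3 in this assay is therefore expected, which means no readable change beyond the scatter. Compound 3 is estimated at 40000 nM in this assay, with a range from 10000 nM to 150000 nM, and a high chance that again only a limit is reported.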

Compound 3, half-maximal inhibitory concentration in the 5-hydroxytryptamine receptor 3A assay: > 30000 nM
Compound 3 ended at the assay's limit; the forecaster's own chance of this, stated with the estimate: 85%; the middle value lies beyond the limit too.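

In the 5-hydroxytryptamine receptor 3A assay compound 3 gives > 30000 nM as its value, which is a limit of the assay and not a number. Compound 3 thus sits in the 5-hydroxytryptamine receptor 3A assay at the same limit as compound 1 and compound 2, so the steps among these three compounds cannot be read: the limit of > 30000 nM in the 5-hydroxytryptamine receptor 3A assay, at which 3 of the 3 values shown sit.

In a physicochemical assay for solubility, at pH 7.4 (on this read-out lower numbers stand for lower solubility and higher numbers for higher solubility), compound 2 gives 174000 nM and compound 3 gives 196000 nM as values, which is a 1.1-fold higher number from compound 2 to compound 3 (0.05 log units; within the scatter) and so no change beyond the scatter.

The compounds shown leave open whether any change to the shared core would give a readable number in the 5-hydroxytryptamine receptor 3A assay and how far each of the three lies beyond the limit.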